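Swapping the benzyl halide: working notes

A few compounds are considered here, and "the series" means these few. Any claim that something is new, unique, unknown or untested is made for them only; others in the source may bear on it.

- compound 1 `CCOC(=O)c1c(C)nc(-c2cccc(C#N)c2)n1C(C)C`: 9260 nM
- compound 2 `CCOC(=O)c1c(C)nc(-c2cccc(C#N)c2)n1OCc1cccc(F)c1`: 22400 nM

In a functional assay on a cell-free system (plasma, Oryctolagus cuniculus) for inhibition, with stated times of 5 min, 1 min and 6 min (on this read-out lower numbers stand for stronger inhibition and higher numbers for weaker inhibition), compound 2 holds the higher of the two numbers, at 22400 nM. Among the measured compounds shown here, the only measured step is modest: a 2.4-fold higher number from compound 1 to compound 2 (0.38 log units; beyond the scatter), with (3-fluorobenzyl)oxy in place of isopropyl on an aromatic nitrogen.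

Compound 3 `CCOC(=O)c1c(C)nc(-c2cccc(C#N)c2)n1OCc1ccc(Cl)cc1` differs from compound 2 by 4-chlorophenyl in place of 3-fluorophenyl on a saturated chain carbon bound to an oxygen on an aromatic ring. For the measured compounds named here, no measured pair varies this group, so the data give no direct guide. Going by the values given here, the one step available replaced a whole substituent, while this change reads only 3-fluorobenzyl to 4-chlorobenzyl. A smaller move is therefore expected in this assay, most likely none beyond the scatter and in no favoured direction, with compound 2 at 22400 nM as the anchor. The expected step is a 1.1-fold lower number from compound 2 to compound 3 (0.05 log units; within the scatter). The estimate for compound 3 is 20000 nM, with an expected range of 9000 nM to 45000 nM.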

Compound 3, half-maximal inhibitory concentration: 6830 nM
Beside the measured number, compound 3's estimate is 2.9-fold (0.47 log units) above it; measured number below the stated range.
By their numbers in this assay, from the lowest: compounds 3 and 1 (each within the scatter of the next); then compound 2.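

The aryl group on this saturated chain carbon bound to an oxygen is not a silent part of the structure: in this assay, 4-chlorophenyl in place of 3-fluorophenyl gives a 3.3-fold lower number from compound 2 to compound 3 (0.52 log units; beyond the scatter), a step beyond the scatter from a change confined to that group. The comparison with the isopropyl compound gives a 1.4-fold lower number from compound 1 to compound 3 (0.13 log units; within the scatter), so the step seen earlier on going to (3-fluorobenzyl)oxy does not carry over to every benzyloxy group on the aromatic nitrogen. No measurement at hand bears on the reason for this result.

On these data alone, whether the step follows the chlorine or its place on the ring stays open, a question that 3-chlorophenyl or 4-fluorophenyl at this position would address. As far as these compounds go, how an unsubstituted phenyl or a 4-methoxyphenyl would read there is equally open.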